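Swapping the Bromobenzyl Group for a Decyl Chain

This account rests on a few compounds, and the source may have more. Where it says the series, first, only, none or still open, it means among the compounds named here.

Of the compounds shown here, three have so far been tested in a functional assay on A549 cells (Homo sapiens) for inhibition, read by MTT assay; a higher number here means a weaker inhibitor, a lower number a stronger inhibitor. Compound 2 `O=C(CBr)Nc1ccc(C(=O)/C=C/c2cn(Cc3ccc(Br)cc3)nn2)cc1` gives 8670 nM, the lowest of the three numbers. Compound 3 `COc1ccccc1N1CCN(CC(=O)Nc2ccc(C(=O)/C=C/c3cn(Cc4ccc(Br)cc4)nn3)cc2)CC1` gives 34000 nM, and compound 1 `CCCCCCCCCCn1cc(/C=C/C(=O)c2ccc(NC(=O)CN3CCN(C(=O)OC(C)(C)C)CC3)cc2)nn1` gives 45400 nM; both stand beyond the usual scatter from compound 2, which is therefore the strongest inhibitor of the three. Compound 4 `CCCCCCCCCCn1cc(/C=C/C(=O)c2ccc(NC(=O)CBr)cc2)nn1` has not been measured. It differs from compound 2 in one place: nonyl in place of 4-bromophenyl on a saturated chain carbon bound to an aromatic nitrogen. Among the measured compounds shown here, no measured pair shows this change alone. Because compound 1, the only one carrying decyl, gives 45400 nM while also carrying a different amide, a small loss is expected, a 1.5-fold higher number from compound 2 to compound 4 (0.18 log units; within the scatter). Compound 4 is estimated at 13000 nM, within a range from 4000 nM to 40000 nM.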

Compound 4, half-maximal inhibitory concentration: 9740 nM
Beside the measured number, compound 4's estimate is 1.3-fold (0.13 log units) above it; measured number inside the range.
By their numbers in this assay, from the lowest: compounds 2 and 4 (each within the scatter of the next); then compounds 3 and 1 (each within the scatter of the next).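

In this assay, nonyl in place of 4-bromophenyl on a saturated chain carbon bound to an aromatic nitrogen gives a 1.1-fold higher number from compound 2 to compound 4 (0.05 log units; within the scatter) with the rest of the molecule unchanged. For this pair, then, the aromatic ring and its bromine can be replaced by a plain chain with no measurable change in the number. Nothing on hand explains why the two groups read alike. Still open, going by these compounds, is whether a shorter chain such as butyl, or a decyl chain ending in an amine, would read the same. On these data alone, it is also open whether this match holds with the larger amide groups of compound 1 and compound 3.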